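Opening a Ring Amine and Lengthening the Chain

A few compounds are considered here, and "the series" means these few. Any claim that something is new, unique, unknown or untested is made for them only; others in the source may bear on it.

Three compounds share one core. Compound 1 `Cc1ccc2c(c1)CC(CCN(C)C)=C2C(C)c1ccccn1` gives 1450 nM in an assay on CHO-K1 cells for binding affinity to muscarinic acetylcholine receptor M5 (Homo sapiens); on this read-out higher numbers stand for weaker inhibition and lower numbers for stronger inhibition; compound 2 `COc1ccc2c(c1)CC(CCN(C)C)=C2C(C)c1ccccn1` gives 6030 nM, and compound 3 `CC(C1=C(CCN2CCCC2)Cc2ccccc21)c1ccccn1` gives 2000 nM. Compound 3 stands second highest of the three, within the scatter of compound 1 and beyond it from compound 2. Going by the values given here, the one measured step, a 4.2-fold higher number from compound 1 to compound 2 (0.62 log units; beyond the scatter), concerns a substituent on the aromatic ring and does not touch the amine. Compound 4 `CC(C1=C(CCCN(C)C)Cc2ccccc21)c1ccccn1` differs from compound 3 by (dimethylamino)methyl in place of pyrrolidin-1-yl on a saturated chain carbon, two bonds along the chain from a double-bonded ring carbon. Among the compounds with values here, no measured step bears on this change, so compound 4 is expected to sit near compound 3, with a step of a 1.3-fold higher number from compound 3 to compound 4 (0.10 log units; within the scatter) not clearly beyond the scatter. For compound 4 the expected value is 2500 nM, within 800 nM to 8000 nM.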

Compound 4, inhibition constant: 3240 nM
Beside the measured number, compound 4's estimate is 1.3-fold (0.11 log units) below it, within the range that was stated.
By their numbers in this assay, from the lowest: compounds 1, 3, 4 and 2 (each within the scatter of the next, the first and the last beyond it).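

Swapping 2-(pyrrolidin-1-yl)ethyl for 3-(dimethylamino)propyl is the first measured change at the amine end of the chain, and in this assay it gives a 1.6-fold higher number from compound 3 to compound 4 (0.21 log units; within the scatter). On this evidence, the ring amine and the open amine on the longer chain cannot be told apart at this position. Nothing available explains this result. On these data alone, because both the ring and the chain length change at once, their separate contributions remain open. A 3-(pyrrolidin-1-yl)propyl chain would separate them, and a piperidine ring on either chain is also untested here.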